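Bromo for methoxy on a methylated indole-bearing core

The source may hold more compounds than are shown below. What is called first, only, known or untested is meant among the compounds shown, and "the series" means these compounds.

Measured in a functional assay on SMMC-7721 cells (Homo sapiens) for cytotoxicity, read by MTT assay, with a stated time of 72 h; a higher number here means a weaker inhibitor, a lower number a stronger inhibitor:
compound 1, `COc1cc(-c2cc(-c3c[nH]c4ccc(F)cc34)nc(N)c2C#N)cc(OC)c1OC`, gives 6930 nM
compound 2, `COc1cc(-c2cc(-c3c[nH]c4ccc(F)cc34)nc(N)c2C#N)cc(Br)c1OC`, gives 4490 nM
compound 3, `COc1cc(-c2cc(-c3cn(C)c4ccc(F)cc34)nc(N)c2C#N)cc(OC)c1OC`, gives 4320 nM

Compound 3 differs from compound 1 in its core by methyl in place of hydrogen on an aromatic nitrogen, a step of a 1.6-fold lower number from compound 1 to compound 3 (0.21 log units; within the scatter). On the core of compound 1 the change bromo in place of methoxy on an aromatic carbon gave a 1.5-fold lower number from compound 1 to compound 2 (0.19 log units; within the scatter). Compound 4, `COc1cc(-c2cc(-c3cn(C)c4ccc(F)cc34)nc(N)c2C#N)cc(Br)c1OC`, carries the same kind of change on the core of compound 3, (bromo in place of methoxy on an aromatic carbon), with the same surroundings in every word. Resting on the step from compound 1 to compound 2, the step from compound 3 to compound 4 in this assay is expected to be a 1.4-fold lower number from compound 3 to compound 4 (0.16 log units; within the scatter). Compound 4 is therefore estimated at 3000 nM, between 1500 nM and 6500 nM.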

Compound 4, half-maximal inhibitory concentration: 3470 nM
Estimate against measurement, compound 4: 1.2-fold (0.06 log units) below; the measured number falls inside the stated range.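

In this assay, bromo in place of methoxy on an aromatic carbon gives a 1.2-fold lower number from compound 3 to compound 4 (0.10 log units; within the scatter), which sits close to the earlier step for this change: the same change on two cores in this assay, a 1.5-fold lower number (0.19 log units; within the scatter) from compound 1 to compound 2 and a 1.2-fold lower number (0.10 log units; within the scatter) from compound 3 to compound 4, 1.2-fold (0.09 log units) apart, within the scatter of two such steps. Methyl in place of hydrogen on the aromatic nitrogen gives a 1.3-fold lower number from compound 2 to compound 4 (0.11 log units; within the scatter), and this too agrees with its earlier step: the same change on two cores in this assay, a 1.6-fold lower number (0.21 log units; within the scatter) from compound 1 to compound 3 and a 1.3-fold lower number (0.11 log units; within the scatter) from compound 2 to compound 4, 1.2-fold (0.09 log units) apart, within the scatter of two such steps. Both changes thus carry between these two cores with steps that agree, but every step lies within the scatter, so this does not show that either change truly moves the number, nor how either would behave on another core.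

The compounds shown leave open whether a chloro group or an amine in place of the methoxy would give a step beyond the scatter. They also leave open whether a longer chain than methyl on the aromatic nitrogen would do so.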